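The compounds below may be only part of what the source reports. "The series", "measured", "known", "first", "only" and "open" are said of these compounds alone.

Compounds measured in a functional assay on KB cells (Homo sapiens) for antiproliferative activity, read by sulforhodamine B assay, with a stated time of 3 days; a lower number here means that less compound is needed, a higher number that more compound is needed for the effect:

Compound 1, `CCC1=C(O)c2c(oc(-c3ccccc3)cc2=O)C(CC)(CC)C1=O`: compound 1 gives > 236 uM, which is a limit of the assay rather than a number (the limit of > 236 uM in this assay, at which 1 of the 3 values shown sits).
Compound 2, `CCC1=C(O)c2c(oc(-c3cccc(F)c3)cc2=O)C(CC)(CC)C1=O`: compound 2 gives > 56.2 uM, also a limit of the assay (the limit of > 56.2 uM in this assay, at which 1 of the 3 values shown sits).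
Compound 3, `CCC1=C(O)c2c(oc(-c3ccc(C)c(C)c3)cc2=O)C(CC)(CC)C1=O`: compound 3 gives 35.5 uM.

Compound 1 thus stands only at a limit in this assay, and one of the two other values shown is likewise a limit. Compound 4, `CCC1=C(O)c2c(oc(-c3cc(C)c(C)cc3C)cc2=O)C(CC)(CC)C1=O`, differs from compound 1 in one place: 2,4,5-trimethylphenyl in place of phenyl on an aromatic carbon.

For the measured compounds named here, two measured steps bear on this change. The step of an at least 6.6-fold lower number from compound 1 to compound 3 (0.82 log units; beyond the scatter) is the closest comparison, since it also puts methyl groups on the phenyl ring. The step that the two limits leave unreadable from compound 1 to compound 2 gives no readable size. Compound 3 and compound 2 are linked by an at least 1.5-fold lower number from compound 2 to compound 3 (0.19 log units; that floor lies within the scatter), which lies within the scatter.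

Compound 4 carries three methyl groups where compound 3 carries two, so a step of roughly the size seen for compound 3 is expected in this assay: an at least 7.8-fold lower number from compound 1 to compound 4 (0.89 log units; beyond the scatter). The estimate for compound 4 is 30 uM, expected to fall between 10 uM and 100 uM.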

Compound 4, concentration for half-maximal effect: 8.2 uM
Estimate against measurement, compound 4: 3.7-fold (0.56 log units) above, outside the stated range (below it).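

In this assay, for the compounds shown here, a further methyl group on the phenyl ring gives a 4.3-fold lower number from compound 3 to compound 4 (0.64 log units; beyond the scatter), the only step in this set between two compounds that both return a number rather than a limit, so one more methyl on the phenyl ring still shifts the read-out when two are already present. The full change to 2,4,5-trimethylphenyl gives an at least 28-fold lower number from compound 1 to compound 4 (1.45 log units; beyond the scatter), and the comparison with the 3-fluorophenyl compound gives an at least 6.8-fold lower number from compound 2 to compound 4 (0.83 log units; beyond the scatter). Both sizes are floors and not exact distances, since compound 1 and compound 2 stand only at limits: the limit of > 236 uM in this assay, at which 1 of the 4 values shown sits; (the limit of > 56.2 uM in this assay, at which 1 of the 4 values shown sits).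

As far as these compounds go, how much of the effect a single methyl on the phenyl ring would give remains open. So does whether a methoxy group or an amine could take the place of these methyl groups.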